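The source may hold more compounds than are shown below. What is called first, only, known or untested is meant among the compounds shown, and "the series" means these compounds.

Working notes on the series. Compound 1 (`CC[C@@H](Nc1nc(NCc2ccccn2)c2ncn(C(C)C)c2n1)C(O)C(C)(C)C`) and compound 2 (`CC[C@H](Nc1nc(NCc2ccccn2)c2ncn(C(C)C)c2n1)C(C)O`) share the same core and differ in one substituent on a nitrogen on an aromatic ring. In a functional assay on HT-29 cells (Homo sapiens) for inhibition, read by sulforhodamine B assay, with a stated time of 96 h (a lower number here means a stronger inhibitor of growth, a higher number a weaker inhibitor of growth), compound 1 gives 34000 nM and compound 2 gives 20000 nM. Within the data shown here, compound 2 therefore stands within the scatter of the only other measured compound, and the two numbers cannot be ranked.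

The next compound is compound 3 (`CC[C@H](Nc1nc(NCc2ccccn2)c2ncn(C(C)C)c2n1)C(C)(C)O`), and the change is methyl in place of hydrogen on a saturated chain carbon bound to an oxygen on a saturated carbon and two saturated chain carbons. The 1-hydroxyethyl group thus becomes 1-hydroxy-1-methylethyl. Among the measured compounds shown here, only one measured step bears on this: a 1.7-fold lower number from compound 1 to compound 2 (0.23 log units; within the scatter). That step exchanges 1-ethyl-2-hydroxy-3,3-dimethylbutyl for 1-(1-hydroxyethyl)propyl, a larger alteration of the same substituent than the methyl in place of hydrogen considered here, and it stays within the scatter. A single step is thin evidence, so the range is kept wide. No shift beyond the scatter is expected in this assay, and the expected step is a 1.1-fold higher number from compound 2 to compound 3 (0.04 log units; within the scatter). Compound 3 is estimated at 22000 nM, with an expected range of 9000 nM to 50000 nM.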

Compound 3, concentration for 50% growth inhibition: > 50000 nM
Compound 3: only a limit was reported; the forecaster's own chance of this, stated with the estimate: 10%; middle value at least 2.2-fold (0.35 log units) from the limit.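

In this assay compound 3 carries > 50000 nM, which is a limit of the assay and not a number. Among these compounds, on this saturated chain carbon bound to an oxygen, methyl in place of hydrogen gives an at least 2.5-fold higher number from compound 2 to compound 3 (0.39 log units; beyond the scatter), so this single added methyl produces the first step beyond the scatter, whereas the larger exchange of the whole substituent gave a 1.7-fold lower number from compound 1 to compound 2 (0.23 log units; within the scatter). Among the compounds shown here, the exchange of 1-ethyl-2-hydroxy-3,3-dimethylbutyl for 1-(1-hydroxy-1-methylethyl)propyl gives an at least 1.4-fold higher number from compound 1 to compound 3 (0.16 log units; that floor lies within the scatter), a floor that lies within the scatter and so fixes no order for that pair.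

From the compounds shown here alone, how large the step to the 1-hydroxy-1-methylethyl group really is stays open, as only its floor can be read: the limit of > 50000 nM in this assay, at which 1 of the 3 values shown sits. Also open is how this saturated chain carbon responds to other groups, for instance an ethyl group in place of the added methyl, or an amine in place of the hydroxyl, and the compounds shown give no reason for the step.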